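The source may report more compounds than this note shows. Statements on the series, on what has been measured and on what is new or still open speak of the compounds shown alone.

Values so far in a functional assay on MDCK cells (Canis lupus familiaris) for inhibition; a lower number here means that less compound is tolerated, a higher number that more compound is tolerated

- compound 1 `COc1nc(CC2(c3ccccc3)CCCO2)cc(=O)n1C` gives 130000 nM
- compound 2 `CCCOc1nc(CC2(c3ccccc3)CCCO2)cc(=O)n1C` gives 170000 nM
- compound 3 `COc1nc(CC2(C)CCCO2)cc(=O)n1C` gives 1620000 nM

Compound 3 stands highest of the three, at 1620000 nM, and both other numbers lie lower by more than the scatter. The next compound to be read in this assay is compound 4 `CCCOc1nc(CC2(C)CCCO2)cc(=O)n1C`. Its structure departs from that of compound 3 by one change: ethyl in place of hydrogen on a saturated chain carbon bound to an oxygen on an aromatic ring. In other words, methoxy becomes propoxy, with ethyl in place of hydrogen on a saturated chain carbon bound to an oxygen on an aromatic ring.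

One measured step carries this same change, a 1.3-fold higher number from compound 1 to compound 2 (0.12 log units; within the scatter), and it stays within the scatter. It was seen only once, and with phenyl rather than methyl on the saturated ring carbon. The other measured step, a 12-fold higher number from compound 1 to compound 3 (1.10 log units; beyond the scatter), is large, but it reports the change from phenyl to methyl at that ring carbon. It explains nothing about the chain and only places compound 3 at its high level. No step beyond the scatter is therefore expected here, and the expected change is a 1.2-fold higher number from compound 3 to compound 4 (0.07 log units; within the scatter). For compound 4 the estimated value is 1900000 nM, with an expected range from 900000 nM to 3800000 nM.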

Compound 4, half-maximal cytotoxic concentration: 860000 nM
Estimate against measurement, compound 4: 2.2-fold (0.34 log units) above, outside the stated range (below it).
By their numbers in this assay, from the lowest: compounds 1 and 2 (each within the scatter of the next); then compounds 4 and 3 (each within the scatter of the next).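

In this assay, the change from methoxy to propoxy now appears on a second core, and a 1.9-fold lower number from compound 3 to compound 4 (0.28 log units; within the scatter) shows that it again produces no shift beyond the scatter, whether methyl or phenyl sits on the saturated ring carbon: the same change on two cores in this assay, a 1.3-fold higher number (0.12 log units; within the scatter) from compound 1 to compound 2 and a 1.9-fold lower number (0.28 log units; within the scatter) from compound 3 to compound 4, 2.5-fold (0.39 log units) apart, within the scatter of two such steps The change from phenyl to methyl on that ring carbon can now also be read with propoxy in place of methoxy, where a 5.1-fold higher number from compound 2 to compound 4 (0.70 log units; beyond the scatter) points the same way as the step seen with methoxy: the same change on two cores in this assay, a 12-fold higher number (1.10 log units; beyond the scatter) from compound 1 to compound 3 and a 5.1-fold higher number (0.70 log units; beyond the scatter) from compound 2 to compound 4, 2.5-fold (0.39 log units) apart, within the scatter of two such steps Across these four compounds, therefore, the group on the saturated ring carbon moves the number beyond the scatter, while the chain on the oxygen does not.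

The compounds shown leave open whether a longer chain such as hexyloxy, or an amine carried on the propoxy chain, would keep the number within the scatter of compound 3. They also leave open whether ethyl or cyclohexyl on the saturated ring carbon would give a number closer to those of the methyl compounds or to those of the phenyl compounds.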